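Benzylamino variant of the shared core in this assay

The compounds below may be only part of what the source reports. "The series", "measured", "known", "first", "only" and "open" are said of these compounds alone.

For the measured compounds named here, compound 2 `CCCCNc1nc2c(ncn2-c2ccccc2)c(=O)n1-c1ccc(Cl)cc1` is the only compound here with a number in a functional assay on OVCAR-3 cells (Homo sapiens) for cytotoxicity, read by MTT assay, with a stated time of 72 h; a higher number here means a weaker inhibitor, a lower number a stronger inhibitor: compound 2 gives 94800 nM. Compound 1 `CNc1nc2c(ncn2-c2ccccc2)c(=O)n1-c1ccc(Cl)cc1` returns only a limit, > 100000 nM, in this assay. The step of an at least 1.0-fold lower number from compound 1 to compound 2 (0.02 log units; that floor lies within the scatter) lies within the scatter, against the limit (the limit of > 100000 nM in this assay, at which 1 of the 2 values shown sits). Compound 3 `O=c1c2ncn(-c3ccccc3)c2nc(NCc2ccccc2)n1-c1ccc(Cl)cc1` carries the change (phenyl in place of propyl on a saturated chain carbon bound to a nitrogen on an aromatic ring). Going by the values given here, no measured step touches an aromatic ring at this place, and the one measured step stayed within the scatter, so no shift beyond the scatter is expected for compound 3, with a limit a real possibility. The step of a 1.4-fold lower number from compound 2 to compound 3 (0.13 log units; within the scatter) is the expected outcome. Compound 3 is estimated at 70000 nM, within 25000 nM to 200000 nM.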

Compound 3, half-maximal inhibitory concentration: 46700 nM
The estimate for compound 3 lay 1.5-fold (0.18 log units) above the measured number, and the stated range covers the measured number.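

In this assay, a phenyl on this saturated chain carbon gives the first shift beyond the scatter at this place: a 2.0-fold lower number from compound 2 to compound 3 (0.31 log units; beyond the scatter), a modest change that the alkyl step had not produced. Measured from the methylamino end of the series, the change reads an at least 2.1-fold lower number from compound 1 to compound 3 (0.33 log units; beyond the scatter), which is only a floor. Compound 1 sits at a limit: the limit of > 100000 nM in this assay, at which 1 of the 3 values shown sits.

On these data alone, whether the lower number depends on the aromatic ring stays open, and a cyclohexyl in place of the phenyl would test this. As far as these compounds go, a longer chain carrying the phenyl, or an amine on the phenyl, also remains open.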